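Replacing a Carbon Ring Group with a Methyl

A few compounds are considered here, and "the series" means these few. Any claim that something is new, unique, unknown or untested is made for them only; others in the source may bear on it.

In an ADME assay on BHK cells (Mesocricetus auratus) for cytotoxicity, read by MTT assay, with a stated time of 96 h (a lower number here means that less compound is tolerated, a higher number that more compound is tolerated), compound 3 `O=C(NC(=S)Nc1cccc(C(F)(F)F)c1)[C@H]1C[C@@H]2CC[C@H]1C2` gives 9600 nM and sits level with the other two measured compounds. Compound 1 `FC(F)(F)c1cccc(NC(=S)Nc2ccc(I)cc2)c1` gives 9400 nM and compound 2 `FC(F)(F)c1cccc(NC(=S)Nc2ccc(Cl)cc2)c1` gives 10000 nM and all three values lie within the usual scatter of one another.

Compound 4 `CC(=O)NC(=S)Nc1cccc(C(F)(F)F)c1` differs from compound 3 in one place (one carbon atom in place of a group of 7 heavy atoms (7 carbon; 2 five-membered non-aromatic rings of carbon only), on a carbonyl carbon). In short, one carbon atom, a methyl, stands in place of a group of 7 heavy atoms with 2 five-membered non-aromatic rings of carbon only, on a carbonyl carbon.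

Going by the values given here, only one measured step changes a single place (a 1.1-fold higher number from compound 1 to compound 2 (0.03 log units; within the scatter)) and it puts chloro in place of iodo on an aromatic carbon. That step is small and within the scatter, but it is a different change and says little here. Among the compounds with values here, no measured step tests the group on the carbonyl carbon. Still, compound 3 (9600 nM) and compound 1 (9400 nM) differ in more than one place and remain within the scatter of each other, so no step beyond the scatter is expected in this assay in either direction. The expected step is small (a 1.1-fold higher number from compound 3 to compound 4 (0.06 log units; within the scatter)) although the size of the structural change leaves real uncertainty. For compound 4 the estimated value is 11000 nM with an expected range of 5000 nM to 30000 nM around it.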

Compound 4, half-maximal cytotoxic concentration: > 100000 nM
Compound 4 ended at the assay's limit; the forecaster's own chance of this, stated with the estimate: 20%; middle value at least 9.0-fold (0.95 log units) from the limit.
By their numbers in this assay, from the lowest: compounds 1, 3 and 2 (each within the scatter of the next). At a limit, above all of these: compound 4.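

In this assay the reading for compound 4 is a limit of the assay and not a number: the limit of > 100000 nM in this assay, at which 1 of the 4 values shown sits.

Placing a methyl on the carbonyl carbon, in place of the group of 7 heavy atoms, gives an at least 10-fold higher number from compound 3 to compound 4 (1.01 log units; beyond the scatter), so this position can change how much compound the cells tolerate by a large margin, something the earlier compounds could not show. Compared with the two compounds carrying a halogen, acetyl in place of 4-chlorophenyl on an amide-type nitrogen gives an at least 10-fold higher number from compound 2 to compound 4 (1.00 log units; beyond the scatter), and acetyl in place of 4-iodophenyl gives an at least 10-fold higher number from compound 1 to compound 4 (1.02 log units; beyond the scatter), which sets compound 4 apart from the three compounds that sit level with one another.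

As far as these compounds go, the full size of these steps stays open. Also open, from the compounds shown here alone, is whether tolerance falls gradually or abruptly as the group on the carbonyl carbon grows from a methyl, through an ethyl or a longer chain, to a single ring of carbon, and whether an amine in that place would match the methyl.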